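Nitro in place of methyl, both neighbours at the limit

The source may report more compounds than this note shows. Statements on the series, on what has been measured and on what is new or still open speak of the compounds shown alone.

Compound 1 `Cn1c(-c2ccccc2Cl)cnc1NC(=O)c1ccc(F)cc1` and compound 2 `Cc1ccccc1-c1cnc(NC(=O)c2ccc(F)cc2)n1C` share a core. In a toxicity assay on THP-1 cells (Homo sapiens) for inhibition (a lower number here means that less compound is tolerated, a higher number that more compound is tolerated), compound 1 gives > 50000 nM, a limit and not a number. In this assay compound 2 gives > 50000 nM, also a limit, so its standing is the limit of > 50000 nM in this assay, at which 2 of the 2 values shown sit. Compound 3 `Cn1c(-c2ccccc2[N+](=O)[O-])cnc1NC(=O)c1ccc(F)cc1` differs from compound 2 by nitro in place of methyl on an aromatic carbon. For the measured compounds named here, the one measured step bearing on it is a step that the two limits leave unreadable from compound 1 to compound 2, so no size carries over, and no shift beyond the scatter is expected in this assay. The expected step is a number no higher from compound 2 to compound 3 (the limit leaves the size open). Compound 3 is estimated at 50000 nM, with an expected range from 20000 nM to 100000 nM.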

Compound 3, half-maximal cytotoxic concentration: 31000 nM
For compound 3 the middle estimate is 1.6-fold (0.21 log units) above the measured one, and the stated range covers the measured number.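

In this assay, for the compounds shown here, compound 3 gives 31000 nM, so nitro at this position, ortho to a large group, provides the first number that is not a limit. Nitro in place of methyl gives an at least 1.6-fold lower number from compound 2 to compound 3 (0.20 log units; that floor lies within the scatter), and nitro in place of chloro gives an at least 1.6-fold lower number from compound 1 to compound 3 (0.20 log units; that floor lies within the scatter), so a shift beyond the scatter is neither shown nor excluded. Compound 1 and compound 2 each stay at a limit, and the step between them cannot be read: the limit of > 50000 nM in this assay, at which 2 of the 3 values shown sit.

Open, as far as these compounds go, is how an amine or a carboxylic acid on this aromatic carbon would read in this assay.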